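Replacing methoxy with amino in a biphenyl cytotoxicity series

This account rests on a few compounds, and the source may have more. Where it says the series, first, only, none or still open, it means among the compounds named here.

Two compounds of this series have been run in an ADME assay on HEK293 cells (Homo sapiens) for cytotoxicity, read by MTT assay, with a stated time of 3 days; a lower number here means a stronger inhibitor, a higher number a weaker inhibitor. Compound 1 `COc1ccccc1-c1ccccc1O` gives 54 ug/mL in this assay. Compound 2 `COc1ccccc1-c1cccc(O)c1` gives 50 ug/mL in this assay. Compound 2 holds the lowest of the two numbers, but its nearest neighbour is compound 1, and the gap between the two falls inside the scatter of repeated runs, so the two values read as one level rather than as a difference.

The next compound, compound 3 `Nc1ccccc1-c1cccc(O)c1`, has not been measured in this assay. Compound 3 differs from compound 2 in one place: amino in place of methoxy on an aromatic carbon. For the measured compounds named here, no measured pair in this set shows the effect of that exchange, so the size of the step has no precedent here. Given that compound 1 with 54 ug/mL and compound 2 with 50 ug/mL sit at the same level, the expectation is that compound 3 stays near that level, with the step of a 1.3-fold lower number from compound 2 to compound 3 (0.10 log units; within the scatter) expected to be small and no more than the scatter would allow. Compound 3 is estimated at 40 ug/mL in this assay, with a range from 18 ug/mL to 90 ug/mL.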

Compound 3, half-maximal inhibitory concentration: 10.5 ug/mL
Compound 3: the middle estimate sits 3.8-fold (0.58 log units) above what was measured; the whole stated range lies above it.
By their numbers in this assay, from the lowest: compound 3; then compounds 2 and 1 (each within the scatter of the next).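

In this assay, amino in place of methoxy on an aromatic carbon, ortho to a group of 7 heavy atoms, gives a 4.8-fold lower number from compound 2 to compound 3 (0.68 log units; beyond the scatter). For the compounds shown here, this is the only step in the set so far, and it shows that this position of the shared core is not indifferent to its substituent: a single exchange here moves the number beyond the scatter, whereas the values of compound 1 and compound 2 alone showed one level. The exchange replaces a group with 0 hydrogen-bond donors by one with 1 hydrogen-bond donor and also changes the heavy-atom count, but nothing measured here bears on which of these differences matters, and the reading rests on this one pair.

A hydroxy, methyl or dimethylamino group at the same place would be needed to tell whether the step belongs to amino itself or would appear with other replacements for methoxy. Also open, from the compounds shown here alone, is whether the same exchange gives a step of similar size on the core of compound 1, where the hydroxy group sits elsewhere.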